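The source may report more compounds than this note shows. Statements on the series, on what has been measured and on what is new or still open speak of the compounds shown alone.

Measured so far:

- Compound 1, `COc1ccc(/C=N/NC(=O)c2ccc(C)cc2O)cc1`: in an ADME assay on cells (Mus musculus, strain BALB/C) for cytotoxicity, read by MTT assay, with a stated time of 24 h (a higher number here means that more compound is tolerated, a lower number that less compound is tolerated), compound 1 gives 723000 nM.
- Compound 2, `Cc1ccc(C(=O)N/N=C/c2cc(Cl)cc(Cl)c2O)c(O)c1`: in this assay compound 2 gives 708000 nM.

Compound 2 holds the lower of the two numbers seen so far, but its nearest neighbour, compound 1, sits within the usual scatter of it, so the two measurements cannot be told apart. Both compounds share the same core and differ only in the ring carrying the hydrazone, yet this brings no visible change in how much compound the cells tolerate.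

The unmeasured compound 3, `Cc1ccc(C(=O)N/N=C/c2cc(Cl)ccc2O)c(O)c1`, is compound 2 with one change: hydrogen in place of chloro on an aromatic carbon. One chlorine is lost from the ring that carries the hydroxy group, on the position meta to the remaining chloro group.

Going by the values given here, no step between measured compounds is available to show what the loss of a chloro group does here. Given that compound 1 and compound 2, despite their different ring substitution, sit within the scatter of each other, the step of a 1.1-fold higher number from compound 2 to compound 3 (0.05 log units; within the scatter) is expected to be small, with at most a modest drift towards a higher number. Compound 3 is therefore estimated at 800000 nM, within a range from 400000 nM to 1600000 nM.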

Compound 3, half-maximal cytotoxic concentration: 560000 nM
Compound 3: middle estimate off by 1.4-fold (0.15 log units), on the high side; the measured number falls inside the stated range.
By their numbers in this assay, from the lowest: compounds 3, 2 and 1 (each within the scatter of the next).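

In this assay, going by these compounds alone, this pair gives the first direct reading of what this position contributes: a 1.3-fold lower number from compound 2 to compound 3 (0.10 log units; within the scatter). Replacing the chloro group ortho to a hydroxy group with hydrogen therefore leaves the two compounds within the usual scatter of repeated measurements, so this loss of one chlorine atom produces no difference that the assay can distinguish. This single step shows that, with the other chloro group absent from neither compound's comparison point and the rest of the molecule unchanged, chloro and hydrogen cannot be told apart here, and no measurement bears on the reason for this result.

Still open, from the compounds shown here alone, is whether this position tolerates any group, or only these two: an amine or a carboxylic acid on the same aromatic carbon might leave the number within the scatter or move it well beyond. Equally open, going by these compounds, is whether the chloro group that remains in compound 3, meta to the position studied here, could also give way to hydrogen without a distinguishable difference.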